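The source may hold more compounds than are shown below. What is called first, only, known or untested is meant among the compounds shown, and "the series" means these compounds.

Of the compounds shown here, three that share one core have been tested in a functional assay on HT-29 cells (Homo sapiens) for cytotoxicity, read by MTT assay, with a stated time of 72 h; a higher number here means a weaker inhibitor, a lower number a stronger inhibitor. Compound 1 `COc1cc2c(Oc3ccc(NC(=O)c4nn(-c5ccccc5)c(=O)c5ccccc45)cc3F)ccnc2cc1OCCCN1CCCCC1` gives 1310 nM. Compound 2 `COc1cc2c(Oc3ccc(NC(=O)c4nn(-c5ccccc5F)c(=O)c5ccccc45)cc3F)ccnc2cc1OCCCN1CCCCC1` gives 630 nM. Compound 3 `COc1cc2c(Oc3ccc(NC(=O)c4nn(-c5ccc([N+](=O)[O-])cc5)c(=O)c5ccccc45)cc3F)ccnc2cc1OCCCN1CCCCC1` gives 2170 nM; between these, a 1.7-fold higher number from compound 1 to compound 3 (0.22 log units; within the scatter), whereas a 3.4-fold higher number from compound 2 to compound 3 (0.54 log units; beyond the scatter). Compound 4 `COc1cc2c(Oc3ccc(NC(=O)c4nn(-c5ccc([N+](=O)[O-])cc5)c(=O)c5ccccc45)cc3F)ccnc2cc1OCCCN1CCC(C)CC1` has not yet been measured. It differs from compound 3 by methyl in place of hydrogen on a saturated ring carbon. Going by the values given here, none of the measured steps bears on this change: each of them alters the group on the aromatic nitrogen, far from the saturated ring, so no precedent exists for adding a methyl there. With nothing pointing either way, the expected step is a 1.0-fold higher number from compound 3 to compound 4 (0.01 log units; within the scatter), a change no larger than the usual scatter. Compound 4 is therefore estimated at 2200 nM, with a likely range from 900 nM to 5500 nM.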

Compound 4, half-maximal inhibitory concentration: 2450 nM
Estimate against measurement, compound 4: 1.1-fold (0.05 log units) below; low and high end bracket the measured number.
By their numbers in this assay, from the lowest: compound 2; then compounds 1, 3 and 4 (each within the scatter of the next).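

In this assay, compounds 1, 2 and 3 differ only in the group on the aromatic nitrogen, whereas replacing piperidin-1-yl with 4-methylpiperidin-1-yl gives a 1.1-fold higher number from compound 3 to compound 4 (0.05 log units; within the scatter). A methyl on this saturated ring carbon, three ring bonds from the ring nitrogen, therefore makes no difference beyond the scatter when 4-nitrophenyl sits on the aromatic nitrogen. No supporting measurement explains this result. Going by these compounds, it remains open whether a hydroxyl, a primary amine or a phenyl ring at this carbon would behave the same way, and whether methyl would do so alongside the 2-fluorophenyl group of compound 2.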